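Replacing the Vinyl Group of Compound 2

The source may hold more compounds than are shown below. What is called first, only, known or untested is meant among the compounds shown, and "the series" means these compounds.

Compound 1 `C=C[C@@](C)(/C=C/c1ccc(OC(C)=O)cc1)CCC=C(C)C`: 63%
Compound 2 `C=C[C@@](C)(/C=C/c1ccc(OC)cc1)CCC=C(C)C`: 29%

Within the data shown here, in a functional assay on THP-1 cells (Homo sapiens) for inhibition, with a stated time of 48 h, tested at 30 uM (on this read-out lower numbers stand for less inhibition of growth and higher numbers for more inhibition of growth at the one concentration tested), compound 2 gives 29%, the lower of the two numbers so far. Among the measured compounds shown here, only one step has been measured: a number 34 percentage points lower from compound 1 to compound 2 (beyond the scatter). It comes with methyl in place of acetyl on an oxygen on an aromatic ring, and it is large.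

Compound 3 `COc1ccc(/C=C/[C@](C)(/C=C/c2ccc(O)cc2)CCC=C(C)C)cc1` keeps that methyl and differs elsewhere, with 2-(4-hydroxyphenyl)ethenyl in place of vinyl on a saturated chain carbon bound to a double-bonded chain carbon and two saturated chain carbons. For the measured compounds named here, no measured step covers a change at this place, so the guidance is only indirect. The step of a number 34 percentage points lower from compound 1 to compound 2 (beyond the scatter) shows that one local change can move this read-out far, and compound 1 at 63% shows that a closely related structure can reach a higher number. A moderate rise therefore seems more likely than a fall, though either direction remains possible. The expected change is a number 13 percentage points higher from compound 2 to compound 3 (beyond the scatter). For compound 3 the estimate is 42%, with an expected range from 18% to 70%.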

Compound 3, percent growth inhibition at one concentration: 60%
The estimate for compound 3 lay 18 percentage points below the measured number; the range from low to high includes it.
By their numbers in this assay, from the lowest: compound 2; then compounds 3 and 1 (each within the scatter of the next).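

In this assay, the saturated chain carbon bound to a double-bonded chain carbon and two saturated chain carbons proves to be a second place where a single change can move the number far, alongside the oxygen on the aromatic ring seen earlier. Putting 2-(4-hydroxyphenyl)ethenyl in place of vinyl there brings a number 31 percentage points higher from compound 2 to compound 3 (beyond the scatter), so this position tolerates a much larger group than vinyl without any loss on this read-out, and the number rises. No measured information explains the gain, and the new group brings an aromatic ring, a hydrogen-bond donor and a hydrogen-bond acceptor all at once, so the step cannot be assigned to any one of these.

The compounds shown leave open whether the ring alone is enough or the hydroxyl on it is needed, a question that a plain phenyl ring or one carrying an amine in place of the hydroxyl would help to settle. They also leave open whether a simple longer chain at this position, with no ring at all, would shift the number in the same direction.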